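The source may report more compounds than this note shows. Statements on the series, on what has been measured and on what is new or still open speak of the compounds shown alone.

Of the compounds shown here, three of a shared core have been measured in an assay (strain Wistar) for inhibition of Amine oxidase [flavin-containing] A (Rattus norvegicus); on this read-out lower numbers stand for stronger inhibition and higher numbers for weaker inhibition. Compound 1 `NC(=O)[C@@H]1CCCN1Cc1cc(=O)oc2cc(OCc3ccccc3)ccc12` gives 35000 nM. Compound 2 `NC(=O)Cc1cc(=O)oc2cc(OCc3ccccc3)ccc12` gives 8000 nM, the lowest of the three numbers, and compound 3 `NC(=O)Cc1cc(=O)oc2cc(OCc3cccc(Cl)c3)ccc12` gives 26000 nM. The two measured steps both lead away from compound 2 toward higher numbers: a 4.4-fold lower number from compound 1 to compound 2 (0.64 log units; beyond the scatter), and a 3.3-fold higher number from compound 2 to compound 3 (0.51 log units; beyond the scatter).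

Compound 4 `CN(C)C(=O)Cc1cc(=O)oc2cc(OCc3ccccc3)ccc12` differs from compound 2 in one place: dimethylamino in place of amino on a carbonyl carbon. Among the compounds with values here, no measured pair shows this kind of change at the carbonyl carbon. The step from compound 1 to compound 2 touches the same carbamoylmethyl side chain, but at the saturated chain carbon rather than at the amide nitrogen, and the step from compound 2 to compound 3 lies on a distant aromatic carbon. What the two steps do show is that each change made to compound 2 so far has produced a modest rise in this assay. On that thin basis, the number for compound 4 is expected to rise modestly, and the expected step is a 2.0-fold higher number from compound 2 to compound 4 (0.30 log units; within the scatter). The estimate for compound 4 is therefore 16000 nM, with a range from 5000 nM to 50000 nM.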

Compound 4, half-maximal inhibitory concentration: 23100 nM
For compound 4 the middle estimate is 1.4-fold (0.16 log units) below the measured one; measured number inside the range.
By their numbers in this assay, from the lowest: compound 2; then compounds 4, 3 and 1 (each within the scatter of the next).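

In this assay, within the data shown here, the first change made at the carbonyl carbon itself, dimethylamino in place of amino, gives a 2.9-fold higher number from compound 2 to compound 4 (0.46 log units; beyond the scatter), so this position does respond to what sits on the carbonyl carbon, and the amino group of compound 2 gives the lowest number so far. The step from the amino group, counted as a hydrogen-bond donor, to dimethylamino, counted as none, is the only one here at this position, and compound 2 now stands apart beyond the scatter from each of the other three compounds, while a 1.5-fold lower number from compound 1 to compound 4 (0.18 log units; within the scatter) does not separate the dimethylcarbamoyl side chain from the 2-carbamoylpyrrolidin-1-yl one. Nothing in hand accounts for the rise in the number from compound 2 to compound 4.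

The compounds shown leave open whether methylamino, with a single methyl on the nitrogen, would sit nearer to compound 2 or to compound 4, and how a pyrrolidin-1-yl group or a hydroxyl giving a carboxylic acid would read on the same carbonyl carbon. They also leave open whether dimethylamino would bring a similar step on the chloro-bearing compound 3.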